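This account rests on a few compounds, and the source may have more. Where it says the series, first, only, none or still open, it means among the compounds named here.

Three compounds have numbers in a functional assay on ileum (Cavia porcellus) for antagonist activity, with a stated time of 30 s; a lower number here means a stronger inhibitor, a higher number a weaker inhibitor: compound 1 (`O=C(O)c1cc(=O)c2cc(CCCc3ccccc3)ccc2o1`) gives 3 ug/mL, compound 2 (`O=C(O)c1cc(=O)c2ccc(OCCCCCCCOc3ccccc3)cc2o1`) gives 1.8 ug/mL and compound 3 (`O=C(O)c1cc(=O)c2ccc(OCCCCCCCCCOc3ccccc3)cc2o1`) gives 1.8 ug/mL. Compound 2 is thus level with compound 3 at the lowest number of the set, and its gap to compound 1 lies within the usual scatter of repeated measurements.

Compound 4 (`O=C(O)c1cc(=O)c2ccc(OCCCCCc3ccccc3)cc2o1`) has not yet been measured. Its change from compound 2 is phenyl in place of 2-phenoxyethyl on a saturated chain carbon, five bonds along the chain from an oxygen on an aromatic ring. Among the measured compounds shown here, the one measured step that alters such a chain end shows no change at the digits printed from compound 2 to compound 3 (within the scatter). Within the scatter of compound 2 stands compound 1, the only measured compound with phenyl and no phenoxy, at 3 ug/mL. No step beyond the scatter is therefore expected in this assay, and these data favour no clear direction. The expected change is a 1.2-fold higher number from compound 2 to compound 4 (0.09 log units; within the scatter). Compound 4 is estimated at 2.2 ug/mL, with an expected range from 1 ug/mL to 5 ug/mL.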

Compound 4, half-maximal inhibitory concentration: 0.6 ug/mL
For compound 4 the middle estimate is 3.7-fold (0.56 log units) above the measured one; measured number below the stated range.
By their numbers in this assay, from the lowest: compound 4; then compounds 2, 3 and 1 (each within the scatter of the next).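

In this assay, the end of the chain at this position proves not to be indifferent: phenyl in place of 2-phenoxyethyl gives a 3.0-fold lower number from compound 2 to compound 4 (0.48 log units; beyond the scatter), whereas the earlier step at a chain end, no change at the digits printed from compound 2 to compound 3 (within the scatter), showed nothing beyond the scatter. This change shortens the chain and removes its ether oxygen in a single move, so the step reports the two together and cannot assign the gain to either one. Nothing measured here accounts for the drop in the number.

Still open, from the compounds shown here alone, is whether a chain of the same length as in compound 2 but ending in phenyl, with no oxygen, would keep this gain. Also open, going by these compounds, is how other chain ends, such as a cyclohexyl ring or an amine, would behave at this place.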